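The compounds below may be only part of what the source reports. "The series", "measured", "known", "first", "only" and "open" are said of these compounds alone.

Compound 1 `COc1ccc(/C=C/C(=O)Nc2ccc3ncnc(Nc4cccc(Br)c4)c3c2)cc1` gives 1.24 ug/mL in a functional assay on B16-F10 cells (Mus musculus) for inhibition, read by MTT assay, with a stated time of 48 h; a lower number here means a stronger inhibitor, a higher number a weaker inhibitor.
Compound 2 `O=C(/C=C/c1cccs1)Nc1ccc2ncnc(Nc3cccc(Br)c3)c2c1` gives 2.51 ug/mL in this assay.
Compound 3 `O=C(/C=C/c1ccc([N+](=O)[O-])cc1)Nc1ccc2ncnc(Nc3cccc(Br)c3)c2c1` gives 0.982 ug/mL in this assay.

All three share the same core and differ only in the group at the far end of the double-bonded chain. Compound 3 has the lowest of the three numbers. Against compound 1 the gap is small: a 1.3-fold lower number from compound 1 to compound 3 (0.10 log units; within the scatter). Against compound 2 it is larger: a 2.6-fold lower number from compound 2 to compound 3 (0.41 log units; beyond the scatter), and a 2.0-fold higher number from compound 1 to compound 2 (0.31 log units; beyond the scatter) shows a change at the same end of the molecule moving the number the other way. Compound 3 can therefore be called stronger than compound 2 but not than compound 1.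

Compound 4 `O=C(/C=C/c1ccc([N+](=O)[O-])cc1)Nc1ccc2ncnc(Nc3cccc(Cl)c3)c2c1` keeps the nitro-bearing end of compound 3 and alters the other end of the molecule: chloro in place of bromo on an aromatic carbon. Among the measured compounds shown here, none of the three measured steps touches this part of the structure, so no measured step bears directly on this change. The step from compound 3 to compound 4 in this assay is therefore expected to be small, probably within the scatter, with no clear direction: a 1.0-fold higher number from compound 3 to compound 4 (0.01 log units; within the scatter). Compound 4 is estimated to give 1 ug/mL, with a range from 0.5 ug/mL to 2 ug/mL.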

Compound 4, half-maximal inhibitory concentration: 2.05 ug/mL
The estimate for compound 4 lay 2.1-fold (0.31 log units) below the measured number; the measured number lies above the stated range.
By their numbers in this assay, from the lowest: compounds 3, 1, 4 and 2 (each within the scatter of the next, the first and the last beyond it).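

The halogen on the 3-bromophenyl ring turns out not to be a silent position: in this assay, chloro in place of bromo gives a 2.1-fold higher number from compound 3 to compound 4 (0.32 log units; beyond the scatter), so compound 3 can be called the stronger inhibitor of this pair. Among the compounds shown here, this is the first measured change at this end of the molecule, and it is a modest step beyond the scatter, even though one halogen atom simply replaces another and the counts of rings, hydrogen-bond donors, hydrogen-bond acceptors and charge all stay the same. No measurement here accounts for why this exchange shifts the number.

As far as these compounds go, this conclusion rests on a single pair of compounds with the 4-nitrophenyl group at the far end, so it remains open whether chloro in place of bromo would move the number in the same direction with 4-methoxyphenyl or thiophen-2-yl there instead. Also open, from the compounds shown here alone, is how a fluoro group, a methyl group or an amine on this same aromatic carbon would compare with bromo and chloro.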